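This account rests on a few compounds, and the source may have more. Where it says the series, first, only, none or still open, it means among the compounds named here.

Compound 3 `COc1ccc(-n2cc(NC(=O)c3cccc(NS(=O)(=O)c4ccccc4)c3)cn2)cc1` sits second highest of the three numbers recorded so far: in a functional assay on HepG2 cells (Homo sapiens) for inhibition, read by MTT assay, with a stated time of 48 h (a higher number here means a weaker inhibitor, a lower number a stronger inhibitor), compound 3 gives 35700 nM. The weakest of the set is compound 1 `Cn1cc(NC(=O)c2cccc(NS(=O)(=O)c3ccccc3)c2)cn1`, which in this assay gives 85300 nM, while compound 2 `Cc1ccc(-n2cc(NC(=O)c3cccc(NS(=O)(=O)c4ccccc4)c3)cn2)cc1` gives 6050 nM in this assay and so stands lowest. The steps among them are all beyond the scatter: a 14-fold lower number from compound 1 to compound 2 (1.15 log units; beyond the scatter), a 2.4-fold lower number from compound 1 to compound 3 (0.38 log units; beyond the scatter), and a 5.9-fold higher number from compound 2 to compound 3 (0.77 log units; beyond the scatter).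

Compound 4 `COc1cccc(-n2cc(NC(=O)c3cccc(NS(=O)(=O)c4ccccc4)c3)cn2)c1` differs from compound 3 by 3-methoxyphenyl in place of 4-methoxyphenyl on an aromatic nitrogen. Among the measured compounds shown here, none of the measured steps moves a substituent around the phenyl ring that sits on the aromatic nitrogen; they only swap the whole group on that nitrogen or exchange methyl for methoxy on an aromatic carbon. What they do show is that this part of the molecule carries weight in this assay, with both the large step from compound 1 to compound 2 and the modest step from compound 2 to compound 3 beyond the scatter. For the measured compounds named here, with no step that tests the position of the methoxy group, the expectation for compound 4 is a step of only modest size in this assay, with no firm direction, a 1.4-fold lower number from compound 3 to compound 4 (0.15 log units; within the scatter). The estimate for compound 4 is therefore 25000 nM, expected to fall between 8000 nM and 80000 nM.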

Compound 4, half-maximal inhibitory concentration: 25000 nM
The estimate for compound 4 equals the measured number at the digits printed; low and high end bracket the measured number.
By their numbers in this assay, from the lowest: compound 2; then compounds 4 and 3 (each within the scatter of the next); then compound 1.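

Shifting the methoxy group from 4-methoxyphenyl to 3-methoxyphenyl on the aromatic nitrogen is the first change here that tests position on that phenyl ring, and in this assay it stays within the scatter (a 1.4-fold lower number from compound 3 to compound 4 (0.15 log units; within the scatter)). For methoxy, then, these two positions cannot be told apart in this assay, and the 3-methoxyphenyl group takes the same intermediate standing as the 4-methoxyphenyl group: it gives a weaker result than 4-methylphenyl (a 4.1-fold higher number from compound 2 to compound 4 (0.62 log units; beyond the scatter)) and a stronger one than methyl (a 3.4-fold lower number from compound 1 to compound 4 (0.53 log units; beyond the scatter)), with both steps beyond the scatter. Nothing available accounts for these numbers.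

As far as these compounds go, whether position is equally silent for other groups stays open, since only methoxy has been moved and a 3-methylphenyl group would be the direct counterpart to compound 2. The compounds shown also leave open how an amine or a carboxylic acid on that phenyl ring would read in this assay, and the rest of the shared core is unchanged across all four, so they say nothing about its parts.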